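A few compounds are considered here, and "the series" means these few. Any claim that something is new, unique, unknown or untested is made for them only; others in the source may bear on it.

Measured compounds:
- compound 1, `CC1=C(C(=O)NCCCN2CCC(c3ccccc3C#N)CC2)[C@@H](c2ccc(F)c(F)c2)NC(=O)N1`: 0.25 nM
- compound 2, `N#Cc1cc(F)ccc1C1CCN(CCCNC(=O)C2=CNC(=O)N[C@@H]2c2ccc(F)c(F)c2)CC1`: 0.07 nM

In an assay on CHO cells with Alpha-1A adrenergic receptor (Homo sapiens) as the target (a lower number here means a stronger inhibitor, a higher number a weaker inhibitor), compound 2 gives the lowest of the two numbers, and compound 1 stands above it by a margin beyond the scatter. Compound 3, `CC1=C(C(=O)NCCCN2CCC(c3ccc(F)cc3C#N)CC2)[C@@H](c2ccc(F)c(F)c2)NC(=O)N1`, differs from compound 2 by methyl in place of hydrogen on a double-bonded ring carbon, a methyl in place of hydrogen on a double-bonded ring carbon. Going by the values given here, no measured pair isolates this change, so its size is unknown; a small step in this assay, toward a somewhat higher number and close to the scatter, is expected. Compound 3 is estimated at 0.15 nM, between 0.05 nM and 0.5 nM, which corresponds to an expected step of a 2.1-fold higher number from compound 2 to compound 3 (0.33 log units; beyond the scatter).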

Compound 3, inhibition constant: 0.17 nM
For compound 3 the middle estimate is 1.1-fold (0.05 log units) below the measured one; the range from low to high includes it.
By their numbers in this assay, from the lowest: compound 2; then compounds 3 and 1 (each within the scatter of the next).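

In this assay methyl in place of hydrogen on a double-bonded ring carbon gives a 2.4-fold higher number from compound 2 to compound 3 (0.39 log units; beyond the scatter) as a modest step, the first measured size for this change. Fluoro in place of hydrogen on an aromatic carbon gives a 1.5-fold lower number from compound 1 to compound 3 (0.17 log units; within the scatter) and stays within the scatter, so compound 1 and compound 3 cannot be told apart here. Nothing available explains either step. The compounds shown leave open whether an ethyl group, a chlorine atom or an amine on that double-bonded ring carbon would read closer to hydrogen or to methyl.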